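Swapping the aryl group on compound 3's amine nitrogen

The source may report more compounds than this note shows. Statements on the series, on what has been measured and on what is new or still open speak of the compounds shown alone.

Measured in a functional assay on ECa-109 cells for inhibition, with ECa-109 cell line (Homo sapiens) as the target, read by sulforhodamine B assay; a higher number here means a weaker inhibitor, a lower number a stronger inhibitor:
- compound 1 `O=C1C(Nc2ccc(I)cc2)=CC(=O)c2c1nc1n2[C@H]2OC[C@@H](O)[C@H]2OC1` gives 2530 nM
- compound 2 `Cc1ccc(NC2=CC(=O)c3c(nc4n3[C@H]3OC[C@@H](O)[C@H]3OC4)C2=O)cc1` gives > 4000 nM (a limit)
- compound 3 `COc1ccccc1NC1=CC(=O)c2c(nc3n2[C@H]2OC[C@@H](O)[C@H]2OC3)C1=O` gives > 4000 nM (a limit)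

Compound 3 has no exact number, only a limit of > 4000 nM. This is the limit of > 4000 nM in this assay, at which 2 of the 3 values shown sit. Compound 4 `CCOc1ccc(NC2=CC(=O)c3c(nc4n3[C@H]3OC[C@@H](O)[C@H]3OC4)C2=O)cc1` has not been measured yet, and it differs from compound 3 in one place: 4-ethoxyphenyl in place of 2-methoxyphenyl on an amine nitrogen. In words, 4-ethoxyphenyl stands in place of 2-methoxyphenyl on an amine nitrogen.

Going by the values given here, three measured steps bear on this change, as each swaps the group on that nitrogen or part of it. They are an at least 1.5-fold higher number from compound 1 to compound 2 (0.19 log units; that floor lies within the scatter), an at least 1.5-fold higher number from compound 1 to compound 3 (0.19 log units; that floor lies within the scatter) and a step that the two limits leave unreadable from compound 2 to compound 3. None of them gives a step of readable size beyond the scatter, so no step beyond the scatter is expected here. Compound 4 may well return only a limit too. The expected step is a step that the limit leaves unreadable from compound 3 to compound 4. For compound 4 the estimated value is 4500 nM, with an expected range from 2000 nM to 10000 nM.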

Compound 4, half-maximal inhibitory concentration: > 4000 nM
Compound 4 was reported as a limit (the forecaster's own chance of this, stated with the estimate: 60%); the middle value lies beyond the limit too.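

Compound 4 also gives only a limit, so a 4-ethoxyphenyl group on the amine nitrogen joins the 4-methylphenyl of compound 2 and the 2-methoxyphenyl of compound 3 in yielding no exact number: the limit of > 4000 nM in this assay, at which 3 of the 4 values shown sit. The one step that can be read is an at least 1.5-fold higher number from compound 1 to compound 4 (0.19 log units; that floor lies within the scatter), so the 4-iodophenyl compound is not shown to be truly stronger in this assay. The steps from compound 2 and from compound 3 to compound 4 cannot be read.

Going by these compounds alone, with compound 1 as the only compound that has an exact number, the true order of these four compounds stays open. On these data alone, how an amine, a carboxylic acid or a longer chain in place of ethoxy would read at this position also stays open.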